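The source may hold more compounds than are shown below. What is called first, only, known or untested is meant among the compounds shown, and "the series" means these compounds.

In a functional assay on A2780 cells (Homo sapiens) for cytotoxicity (a lower number here means a stronger inhibitor, a higher number a weaker inhibitor), compound 1 `CC(C)C(=O)Nc1ncc(SCc2ncc(C(C)(C)C)o2)s1` gives 50 nM, while compound 2 `C[C@@H](C(=O)Nc1ncc(SCc2ncc(C(C)(C)C)o2)s1)c1ccccc1` gives 900 nM. For the measured compounds named here, compound 2 therefore holds the higher of the two numbers, and its only measured neighbour is compound 1. Going by the values given here, the single measured step between them is large and beyond the scatter: an 18-fold higher number from compound 1 to compound 2 (1.26 log units; beyond the scatter), with 1-phenylethyl in place of isopropyl on a carbonyl carbon.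

Compound 3 `CC(C)OC(=O)Nc1ncc(SCc2ncc(C(C)(C)C)o2)s1` has not yet been measured. Its difference from compound 2 is isopropoxy in place of 1-phenylethyl on a carbonyl carbon. The measured step bears directly on this change, since 1-phenylethyl leaves again and isopropoxy stands where compound 1 carries isopropyl. Among the compounds with values here, no measured compound carries isopropoxy, so how far the number returns remains open. A large move toward a lower number is nevertheless expected in this assay, with most of the measured step reversed. The expected change is a 6.4-fold lower number from compound 2 to compound 3 (0.81 log units; beyond the scatter). For compound 3 the estimated value is 140 nM, within an estimated range from 40 nM to 500 nM.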

Compound 3, half-maximal inhibitory concentration: 640 nM
For compound 3 the middle estimate is 4.6-fold (0.66 log units) below the measured one; the whole stated range lies below it.
By their numbers in this assay, from the lowest: compound 1; then compounds 3 and 2 (each within the scatter of the next).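

In this assay the exchange of 1-phenylethyl for isopropoxy on the carbonyl carbon gives a 1.4-fold lower number from compound 2 to compound 3 (0.15 log units; within the scatter), so compound 2 and compound 3 cannot be told apart here, even though the ring and the defined stereocentre have gone and only 4 heavy atoms stand where there were 8. Losing 1-phenylethyl is therefore not enough to recover the number of compound 1: the comparison with isopropyl gives a 13-fold higher number from compound 1 to compound 3 (1.11 log units; beyond the scatter), a large step for a change in which the entering group differs from isopropyl by a single oxygen, and of the three groups shown at this place only isopropyl goes with a low number. Nothing available here accounts for this sensitivity, and the result can be stated only as an observed difference between the compounds.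

The compounds shown leave open whether the high number follows the oxygen itself or something specific to isopropoxy as a whole. Nor do they show how a methylamino group, a cyclopropyl group or a tert-butyl group on the same carbonyl carbon would compare with isopropyl in this assay.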